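The compounds below may be only part of what the source reports. "The series", "measured", "known", "first", "only" and "open" are said of these compounds alone.

Measured so far:
compound 1 `CCCn1c(=O)c(S(=O)(=O)c2ccc(F)cc2F)cc2cnc(Nc3ccc4[nH]ccc4c3)nc21` — 1000 nM
compound 2 `Cc1ccc(S(=O)(=O)c2cc3cnc(Nc4ccc5ncccc5c4)nc3n(C)c2=O)cc1` — 10000 nM

In a functional assay on DU-145 cells (Homo sapiens) for inhibition, read by trypan blue exclusion, with a stated time of 72 h (on this read-out higher numbers stand for weaker inhibition and lower numbers for stronger inhibition), compound 1 gives 1000 nM, the lowest of the two numbers; compound 2, with 10000 nM, lies well beyond the usual scatter above it. Compound 3 `O=c1c(S(=O)(=O)c2ccc(F)cc2F)cc2cnc(Nc3ccc4[nH]ccc4c3)nc2n1CC1CCCC1` is not yet measured. It differs from compound 1 in one place: cyclopentyl in place of ethyl on a saturated chain carbon bound to an aromatic nitrogen. Among the compounds with values here, no measured pair shows this change, so the expectation rests on compound 1 alone. A step of no size beyond the scatter is expected, a 1.3-fold lower number from compound 1 to compound 3 (0.10 log units; within the scatter), and compound 3 is estimated at 800 nM, ranging from 250 nM to 3000 nM.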

Compound 3, half-maximal inhibitory concentration: 10000 nM
The estimate for compound 3 lay 13-fold (1.10 log units) below the measured number, outside the stated range (above it).
By their numbers in this assay, from the lowest: compound 1; then compounds 2 and 3 (each within the scatter of the next).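

In this assay, this place on a saturated chain carbon bound to an aromatic nitrogen proves sensitive to the group it carries: cyclopentyl in place of ethyl gives a 10-fold higher number from compound 1 to compound 3 (1.00 log units; beyond the scatter), so inhibition weakens. This is the first single change that can be read among these compounds. No available evidence accounts for the loss. The compounds shown leave open whether the ring itself or simply the added carbons matter. A straight butyl chain or a cyclopropyl ring at the same place could help separate the two.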